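The compounds below may be only part of what the source reports. "The series", "measured", "known", "first", "only" and "open" are said of these compounds alone.

Measured in a physicochemical assay for solubility, in simulated intestinal fluid, at pH 6.8; a lower number here means a less soluble compound, a higher number a more soluble compound:
- compound 1 `O=C(O)c1ccc2nc(N3CCC(OCc4c(-c5c(Cl)cccc5Cl)noc4C4CC4)CC3)sc2c1` gives 61000 nM
- compound 2 `O=C(O)c1ccc2nc(N3CCC(OCc4c(-c5c(F)cccc5F)noc4C4CC4)CC3)sc2c1` gives 169000 nM

Compound 2 holds the higher of the two numbers. Compound 3 `O=C(O)c1ccc2nc(N3CCC(OCc4c(-c5ccccc5C(F)(F)F)noc4C4CC4)CC3)sc2c1` carries 2-(trifluoromethyl)phenyl in place of 2,6-difluorophenyl on an aromatic carbon and has not been measured. Among the measured compounds shown here, one measured step bears on this change: a 2.8-fold higher number from compound 1 to compound 2 (0.44 log units; beyond the scatter) is a modest exchange of one substituted phenyl for another. For the measured compounds named here, no trifluoromethyl compound has a measurement, so the direction is tentative. A move of similar modest size toward compound 1 is expected, and the estimated step is a 2.1-fold lower number from compound 2 to compound 3 (0.32 log units; beyond the scatter) for now. Compound 3 is estimated at 80000 nM with an expected range of 30000 nM to 200000 nM in this assay.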

Compound 3, solubility: 131000 nM
Compound 3: middle estimate off by 1.6-fold (0.21 log units), on the low side, and the stated range covers the measured number.
By their numbers in this assay, from the lowest: compound 1; then compounds 3 and 2 (each within the scatter of the next).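

At this aromatic carbon of the five-membered ring, exchanging 2,6-difluorophenyl for 2-(trifluoromethyl)phenyl gives a 1.3-fold lower number from compound 2 to compound 3 (0.11 log units; within the scatter) in this assay, so these two groups cannot be separated here. With a 2.1-fold higher number from compound 1 to compound 3 (0.33 log units; beyond the scatter), a second group now stands clear of 2,6-dichlorophenyl, which gives the lowest number of the three. No measurement shown accounts for these numbers.

Still open, from the compounds shown here alone, is where unsubstituted phenyl or a pyridyl ring would fall at this position. Also open, going by these compounds, is whether an isopropyl group in place of the cyclopropyl group would shift the number.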